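The source may hold more compounds than are shown below. What is called first, only, known or untested is meant among the compounds shown, and "the series" means these compounds.

Working notes on the series in a functional assay on MCF7 cells (Homo sapiens) for antiproliferative activity, read by MTT assay, with a stated time of 72 h; on this read-out lower numbers stand for stronger inhibition and higher numbers for weaker inhibition:

- compound 1 `O=S(=O)(Oc1ccccc1)C1CC2OC1C(c1ccc(/C=C/c3cc(O)cc(O)c3)cc1)=C2c1ccc(O)cc1`: 20100 nM
- compound 2 `O=S(=O)(Oc1ccc(Cl)cc1)C1CC2OC1C(c1ccc(/C=C/c3cc(O)cc(O)c3)cc1)=C2c1ccc(O)cc1`: 17900 nM
- compound 3 `O=S(=O)(Oc1cccc(Cl)c1)C1CC2OC1C(c1ccc(/C=C/c3cc(O)cc(O)c3)cc1)=C2c1ccc(O)cc1`: 12900 nM

Compound 3, at 12900 nM, lies within the scatter of both other compounds, so no order is claimed among the three. The next compound to read is compound 4 `Cc1ccc(OS(=O)(=O)C2CC3OC2C(c2ccc(/C=C/c4cc(O)cc(O)c4)cc2)=C3c2ccc(O)cc2)cc1`, which carries 4-methylphenyl in place of 3-chlorophenyl on an oxygen whose other neighbour is the sulfonyl sulfur: 4-methylphenyl in place of 3-chlorophenyl on an oxygen.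

Among the compounds with values here, no measured step introduces a methyl group, so the evidence is indirect. The closest guide is the set of changes on the same aryl group. Chloro in place of hydrogen gives a 1.1-fold lower number from compound 1 to compound 2 (0.05 log units; within the scatter) and a 1.6-fold lower number from compound 1 to compound 3 (0.19 log units; within the scatter), and moving from 4-chlorophenyl to 3-chlorophenyl gives a 1.4-fold lower number from compound 2 to compound 3 (0.14 log units; within the scatter). All three steps are small, and none leaves the scatter. On that basis, no shift beyond the scatter is expected in this assay, and no direction can be argued with any confidence. The estimate sits among the three measured values and means a 1.2-fold higher number from compound 3 to compound 4 (0.09 log units; within the scatter). For compound 4 the expected value is 16000 nM. The expected range for compound 4 runs from 9000 nM to 28000 nM.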

Compound 4, half-maximal inhibitory concentration: 9200 nM
Beside the measured number, compound 4's estimate is 1.7-fold (0.24 log units) above it, within the range that was stated.
By their numbers in this assay, from the lowest: compounds 4, 3, 2 and 1 (each within the scatter of the next, the first and the last beyond it).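

In this assay the aryl group on the oxygen whose other neighbour is the sulfonyl sulfur gives its first step beyond the scatter: adding a methyl group to that aryl group gives a 2.2-fold lower number from compound 1 to compound 4 (0.34 log units; beyond the scatter) and is a modest step, while neither chloro step from compound 1 left the scatter. Methyl cannot be separated from chloro on these numbers: methyl in place of chloro gives a 1.9-fold lower number from compound 2 to compound 4 (0.29 log units; within the scatter) and 4-methylphenyl in place of 3-chlorophenyl gives a 1.4-fold lower number from compound 3 to compound 4 (0.15 log units; within the scatter) and both stay within the scatter. The series thus shows that this position can register a small substituent change, but only against the unsubstituted phenyl of compound 1, and no measurement shown accounts for that step.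

The compounds shown carry only phenyl, chlorophenyl and methylphenyl on that oxygen, so it remains open whether a methoxy group, a nitrile or an amine on the same aryl ring would extend the step or leave the numbers within the scatter. From the compounds shown here alone, it also remains open how a longer alkyl chain in place of the aryl group would read out.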